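The compounds below may be only part of what the source reports. "The series", "measured", "known", "first", "only" and "open" are said of these compounds alone.

Measured in a functional assay on HT-29 cells (Homo sapiens) for inhibition, read by MTT assay, with a stated time of 72 h; on this read-out higher numbers stand for weaker inhibition and lower numbers for stronger inhibition:
compound 1 `C=C(Br)C(=O)Nc1cccc(/C=C/C(=O)Nc2ccc(Cl)cc2)c1`: 7900 nM
compound 2 `C=C(Br)C(=O)Nc1cccc(/C=C/C(=O)Nc2ccc(C)cc2)c1`: 1200 nM

Of these two, compound 2 stands lowest at 1200 nM, the stronger inhibitor. Compound 3 `C=C(Br)C(=O)Nc1cccc(/C=C/C(=O)NCc2ccc(C)cc2)c1` carries 4-methylbenzyl in place of 4-methylphenyl on an amide-type nitrogen. Going by the values given here, the only measured step, a 6.6-fold lower number from compound 1 to compound 2 (0.82 log units; beyond the scatter), is methyl in place of chloro on an aromatic carbon. It is a modest step of a different kind and bears only indirectly, as a guide to size, since no change at this nitrogen has been measured. In this assay a modest rise is therefore expected, and the estimated step is a 1.7-fold higher number from compound 2 to compound 3 (0.22 log units; within the scatter). For compound 3 the estimate is 2000 nM, with an expected range of 600 nM to 7000 nM.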

Compound 3, half-maximal inhibitory concentration: 2700 nM
For compound 3 the middle estimate is 1.4-fold (0.13 log units) below the measured one; the range from low to high includes it.
By their numbers in this assay, from the lowest: compound 2; then compound 3; then compound 1.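

In this assay, the group on the amide-type nitrogen itself proves to matter: 4-methylbenzyl in place of 4-methylphenyl gives a 2.3-fold higher number from compound 2 to compound 3 (0.35 log units; beyond the scatter) and so a modest loss of inhibition. The same 4-methylbenzyl group in place of 4-chlorophenyl gives a 2.9-fold lower number from compound 1 to compound 3 (0.47 log units; beyond the scatter) and so a modest gain, which means the direction of the step depends on the group replaced. Nothing available explains either step. Still open, going by these compounds, is whether a longer chain such as 2-(4-methylphenyl)ethyl on this nitrogen would continue the loss seen with 4-methylbenzyl. Also open, on these data alone, is how a benzyl group carrying chloro would compare with 4-methylbenzyl.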